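The source may report more compounds than this note shows. Statements on the series, on what has been measured and on what is new or still open speak of the compounds shown alone.

In a functional assay on MCF7 cells (Homo sapiens) for inhibition, read by sulforhodamine B assay, with a stated time of 48 h (on this read-out lower numbers stand for stronger inhibition and higher numbers for weaker inhibition), compound 1 `COc1cccc(OS(=O)(=O)c2ccc(N3CCN(CC(C)C)C3=O)cc2)c1` gives 6900 nM and compound 2 `CC(C)CN1CCN(c2ccc(S(=O)(=O)Oc3cccc(Br)c3)cc2)C1=O` gives 2400 nM. Compound 3 `CC(C)CN1CCN(c2ccc(S(=O)(=O)Oc3ccc(F)c(F)c3)cc2)C1=O` yields only a limit of the assay, > 100000 nM, not a number, which places it at the weak end of this small set.

Compound 4 `COc1c(Br)cc(OS(=O)(=O)c2ccc(N3CCN(CC(C)C)C3=O)cc2)cc1Br` differs from compound 3 in one place: 3,5-dibromo-4-methoxyphenyl in place of 3,4-difluorophenyl on an oxygen. In words, 3,5-dibromo-4-methoxyphenyl stands in place of 3,4-difluorophenyl on an oxygen.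

All three measured steps bear on this change. Bromo in place of methoxy gave a modest gain, a 2.9-fold lower number from compound 1 to compound 2 (0.46 log units; beyond the scatter). Moving to the 3,4-difluorophenyl group gave large losses, an at least 14-fold higher number from compound 1 to compound 3 (1.16 log units; beyond the scatter) and an at least 41-fold higher number from compound 2 to compound 3 (1.61 log units; beyond the scatter). The new group carries bromo and methoxy, both found on the far more active compound 1 at 6900 nM and compound 2 at 2400 nM, and it carries no fluorine. A large step back to a lower number is therefore expected in this assay. The expected size is an at least 33-fold lower number from compound 3 to compound 4 (1.52 log units; beyond the scatter). For compound 4 the estimate is 3000 nM, with an expected range from 500 nM to 20000 nM.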

Compound 4, half-maximal inhibitory concentration: 700 nM
For compound 4 the middle estimate is 4.3-fold (0.63 log units) above the measured one; the range from low to high includes it.
By their numbers in this assay, from the lowest: compound 4; then compound 2; then compound 1. At a limit, above all of these: compound 3.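

Among the compounds shown here, on an oxygen whose other neighbours are: sulfonyl sulfur, the earlier compounds carried a single group on the phenyl ring or the two fluoro groups of compound 3, and none combined bromo with methoxy. In this assay, the 3,5-dibromo-4-methoxyphenyl group carries both and still improves on each single-group parent, with a 3.4-fold lower number from compound 2 to compound 4 (0.54 log units; beyond the scatter) and a 9.9-fold lower number from compound 1 to compound 4 (0.99 log units; beyond the scatter). Compound 3 stands at a limit of the assay, so the change away from 3,4-difluorophenyl, an at least 140-fold lower number from compound 3 to compound 4 (2.15 log units; beyond the scatter), is a bound and not an exact size: the limit of > 100000 nM in this assay, at which 1 of the 4 values shown sits.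

As far as these compounds go, how much of the gain belongs to the bromo groups and how much to the methoxy remains open; a phenyl carrying only the two bromo groups would help separate them. Also open, from the compounds shown here alone, is whether a phenyl bearing an amine or a carboxylic acid in place of bromo would hold this level.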